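The compounds below may be only part of what the source reports. "The series", "measured", "known", "first", "only" and "open" are said of these compounds alone.

Of the compounds shown here, three built on a shared core have been tested in an ADME assay on HeLa cells (Homo sapiens) for cytotoxicity, read by MTT assay, with a stated time of 72 h; on this read-out higher numbers stand for lower toxicity in this test and lower numbers for higher toxicity in this test. Compound 1 `Oc1ccccc1/C=N/c1sc2c(c1-c1nc3ccccc3s1)CCC2` gives 168 ug/mL in this assay. Compound 3 `Clc1ccccc1/C=N/c1sc2c(c1-c1nc3ccccc3s1)CCCC2` gives 407 ug/mL there, and compound 2 `Clc1ccc(/C=N/c2sc3c(c2-c2nc4ccccc4s2)CCCC3)c(Cl)c1` gives 542 ug/mL. The difference between the cores of compound 1 and compound 3 is not broken down here; compound 1 stands lowest of the three, beyond the scatter from both others. From compound 3 to compound 2 the change is chloro in place of hydrogen on an aromatic carbon, and the step was a 1.3-fold higher number from compound 3 to compound 2 (0.12 log units; within the scatter). Compound 4 `Oc1ccccc1/C=N/c1sc2c(c1-c1nc3cc(Cl)ccc3s1)CCC2` is not yet measured and differs from compound 1 by chloro in place of hydrogen on an aromatic carbon. This is the same kind of change, not the same: in compound 2 the chloro sits meta to a chloro group and para to a large group, whereas in compound 4 it sits on a ring that is part of a fused or bridged system of two rings, meta to a fused ring and para to a fused ring. Compound 4 is expected to give 200 ug/mL in this assay, between 100 ug/mL and 400 ug/mL. The expected step is a 1.2-fold higher number from compound 1 to compound 4 (0.08 log units; within the scatter). That expectation rests on compound 3 and compound 2, whose step a 1.3-fold higher number from compound 3 to compound 2 (0.12 log units; within the scatter) stayed within the scatter, so only a small step from compound 1 is expected.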

Compound 4, half-maximal cytotoxic concentration: 251 ug/mL
Compound 4: middle estimate off by 1.3-fold (0.10 log units), on the low side; measured number inside the range.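

Chloro in place of hydrogen on an aromatic carbon gave a 1.5-fold higher number from compound 1 to compound 4 (0.17 log units; within the scatter) in this assay, and this step reads much like the earlier one on the other core: the same change on two cores in this assay, a 1.3-fold higher number (0.12 log units; within the scatter) from compound 3 to compound 2 and a 1.5-fold higher number (0.17 log units; within the scatter) from compound 1 to compound 4, 1.1-fold (0.05 log units) apart, within the scatter of two such steps. Within this small set, then, the change carried from one core to the other with no step beyond the scatter on either core. Going by these compounds alone, this does not show that chloro makes no difference across the series, as only two pairs stand behind the reading, and the chloro enters a different setting in each, with compound 4 alone carrying it on a ring that is part of a fused or bridged system of two rings.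

The compounds shown leave open whether a different group on that same aromatic carbon, such as a methoxy group, an amine or a carboxylic acid, would give a step beyond the scatter. Also open, from the compounds shown here alone, is what each difference between compound 1 and compound 3 contributes alone, as those two compounds differ in more than one place.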